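The source may hold more compounds than are shown below. What is called first, only, known or untested is meant among the compounds shown, and "the series" means these compounds.

Working notes on the series.

Two compounds of the shared core have been run in a functional assay on the whole organism (strain Kunming) for inhibition, with Mus musculus as the target, in the writhing test, at a dose of 40 mg/kg by the oral route; on this read-out lower numbers stand for less inhibition and higher numbers for more inhibition at the one dose given (going by the name of the read-out). Compound 1 `CCNC(=O)c1cc(-c2ccc(F)cc2F)ccc1OC(C)=O` gives 23.9% in this assay. Among the measured compounds shown here, compound 2 `CC(=O)Oc1ccc(-c2ccc(F)cc2F)cc1C(=O)NCc1ccccc1` gives 16.6% in this assay, the lowest of the two numbers, though its only neighbour is compound 1 and the gap is within the scatter. For the measured compounds named here, the single measured step, a number 7.3 percentage points lower from compound 1 to compound 2 (within the scatter), is therefore read as no change beyond the scatter.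

Compound 3 `CC(=O)Oc1ccc(-c2ccc(F)cc2F)cc1C(=O)Nc1ccccc1C` has not yet been measured in this assay. It differs from compound 2 by 2-methylphenyl in place of benzyl on an amide-type nitrogen. Going by the values given here, no measured pair shows an aromatic ring placed directly on the amide-type nitrogen in place of a saturated chain carbon, so nothing here bears directly on this change. Among the compounds with values here, the one step that exists, from compound 1 to compound 2, altered the group on that nitrogen and stayed within the scatter, which gives no ground to expect a large step in this assay either. Compound 3 is therefore expected to sit close to compound 2, the step of a number 1.4 percentage points higher from compound 2 to compound 3 (within the scatter) being an estimate within the scatter. The estimate for compound 3 in this assay is 18%, with a range from 7% to 31%.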

Compound 3, a percentage reported as inhibition, in the whole organism at one dose (the size of the read-out at that dose, not a potency): 12.3%
Compound 3: the middle estimate sits 5.7 percentage points above what was measured; the range from low to high includes it.
By their numbers in this assay, from the lowest: compounds 3, 2 and 1 (each within the scatter of the next, the first and the last beyond it).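

The aromatic ring placed directly on the amide-type nitrogen, with 2-methylphenyl in place of benzyl, gives in this assay a number 4.3 percentage points lower from compound 2 to compound 3 (within the scatter) and so shows no change beyond the scatter, which means that moving from benzyl to this directly attached ring does not separate the two compounds on this read-out. Among the compounds shown here, the comparison with ethyl on the same nitrogen gives the first step to clear the scatter, a number 11.6 percentage points lower from compound 1 to compound 3 (beyond the scatter), so the group on this nitrogen can shift the read-out, though only modestly, and compound 2 cannot be told apart from either of the other two. Nothing available bears on the reason for this modest step.

The compounds shown do not separate the contribution of the ring from that of its 2-methyl group, so an unsubstituted phenyl on this nitrogen would be the informative comparison. Going by these compounds, how a longer chain such as n-butyl or a chain carrying an amine or a carboxylic acid would read in this assay remains open, as does whether the order seen at this one dose would hold at other doses.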